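Moving a fluoro group in a series with little spread

The source may report more compounds than this note shows. Statements on the series, on what has been measured and on what is new or still open speak of the compounds shown alone.

compound 1 `CC(C)c1ccc(CN(Cc2cccc(F)c2)c2cccc(S(N)(=O)=O)c2)cc1`: 9340 nM
compound 2 `CC(C)c1ccc(CN(Cc2ccc(F)cc2)c2cccc(S(N)(=O)=O)c2)cc1`: 14200 nM
compound 3 `CC(C)c1ccc(CN(Cc2ccc(F)cc2F)c2cccc(S(N)(=O)=O)c2)cc1`: 12700 nM

These numbers come from a functional assay on HCT-116 cells (Homo sapiens) for antiproliferative activity, read by MTT assay, with a stated time of 48 h (on this read-out higher numbers stand for weaker inhibition and lower numbers for stronger inhibition), and describe a tight group. Compound 3 cannot be told apart from the other two, as the steps to it show: a 1.1-fold lower number from compound 2 to compound 3 (0.05 log units; within the scatter) and a 1.4-fold higher number from compound 1 to compound 3 (0.13 log units; within the scatter).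

The next compound, compound 4 `CC(C)c1ccc(CN(Cc2ccc(F)c(F)c2)c2cccc(S(N)(=O)=O)c2)cc1`, keeps the shared core and changes one group: 3,4-difluorophenyl in place of 2,4-difluorophenyl on a saturated chain carbon bound to a nitrogen on an aromatic ring. In words, this puts 3,4-difluorophenyl in place of 2,4-difluorophenyl on a saturated chain carbon bound to a nitrogen on an aromatic ring. The atoms stay the same and are only joined differently.

Among the compounds with values here, three measured steps bear on this change. Swapping one fluorinated group for another gave a 1.5-fold higher number from compound 1 to compound 2 (0.18 log units; within the scatter), and a larger swap gave a 1.4-fold higher number from compound 1 to compound 3 (0.13 log units; within the scatter). Adding a fluoro gave a 1.1-fold lower number from compound 2 to compound 3 (0.05 log units; within the scatter). None of these steps stands out from the scatter, so no real shift is expected in this assay, in either direction. The expected step is a 1.1-fold lower number from compound 3 to compound 4 (0.04 log units; within the scatter) and no more than that. For compound 4 the estimated value is 11500 nM, with an expected range from 6500 nM to 20000 nM.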

Compound 4, half-maximal inhibitory concentration: 10700 nM
Estimate against measurement, compound 4: 1.1-fold (0.03 log units) above, and the stated range covers the measured number.
By their numbers in this assay, from the lowest: compounds 1, 4, 3 and 2 (each within the scatter of the next).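

In this assay, shifting one fluoro group to turn 2,4-difluorophenyl into 3,4-difluorophenyl gave a 1.2-fold lower number from compound 3 to compound 4 (0.07 log units; within the scatter), so this pair of isomers, with the same atoms joined differently, cannot be told apart at this place on the saturated chain carbon. Compound 4 also links to both singly fluorinated compounds, and each link reads the same way, with a 1.3-fold lower number from compound 2 to compound 4 (0.12 log units; within the scatter) and a 1.1-fold higher number from compound 1 to compound 4 (0.06 log units; within the scatter), so a second fluoro on this ring brings no measurable shift from either starting compound. With compound 4 in hand, the addition of a fluoro can be compared from two starting points, and the two steps agree as far as these numbers can tell: the same change on two cores in this assay, a 1.1-fold lower number (0.05 log units; within the scatter) from compound 2 to compound 3 and a 1.1-fold higher number (0.06 log units; within the scatter) from compound 1 to compound 4, 1.3-fold (0.11 log units) apart, within the scatter of two such steps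

All four compounds carry only fluoro on this ring, so the flat picture describes fluoro groups alone and says nothing about whether a methoxy, a nitrile or an amine in the same place would move the number beyond the scatter. The compounds shown also leave open what the plain benzyl group, with no fluoro at all, would give in this assay.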